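The source may report more compounds than this note shows. Statements on the series, on what has been measured and on what is new or still open speak of the compounds shown alone.

Compound 3 `COC(=O)/C=C/c1cccc(N(Cc2ccc(/C=C/C(=O)N(C)C)cc2)C(=O)C2CCCCC2)c1` gives > 1000 nM in an assay on isolated protein with Bile acid receptor (Homo sapiens) as the target (a lower number here means that less compound is needed, a higher number that more compound is needed for the effect), a limit of the assay rather than a number. Compound 1 `COC(=O)/C=C/c1cccc(N(Cc2ccc(/C=C/c3scnc3C)cc2)C(=O)C2CCCCC2)c1` gives 227 nM and compound 2 `COC(=O)/C=C/c1cccc(N(Cc2ccc(-c3ccc(OC)cc3)cc2)C(=O)C2CCCCC2)c1` gives 89 nM; compound 3 thus sits at the limit of > 1000 nM in this assay, at which 1 of the 3 values shown sits, and stands weakest of the three. The steps of an at least 4.4-fold higher number from compound 1 to compound 3 (0.64 log units; beyond the scatter) and an at least 11-fold higher number from compound 2 to compound 3 (1.05 log units; beyond the scatter) both raised the number on arrival at the dimethylcarbamoyl group. Compound 4 `COC(=O)/C=C/c1cccc(N(Cc2ccc(/C=C/c3ccc(F)cc3)cc2)C(=O)C2CCCCC2)c1` differs from compound 3 by 4-fluorophenyl in place of dimethylcarbamoyl on a double-bonded chain carbon bound to a double-bonded chain carbon, so an aromatic ring again occupies the double-bonded chain carbon, as in compound 1. The reverse of an at least 4.4-fold higher number from compound 1 to compound 3 (0.64 log units; beyond the scatter) is the nearest guide, and a step of that order downward is expected. Compound 4 is expected to give 200 nM, between 60 nM and 700 nM. The expected step is an at least 5.0-fold lower number from compound 3 to compound 4 (0.69 log units; beyond the scatter).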

Compound 4, half-maximal effective concentration: 185 nM
The estimate for compound 4 lay 1.1-fold (0.03 log units) above the measured number; measured number inside the range.
By their numbers in this assay, from the lowest: compound 2; then compounds 4 and 1 (each within the scatter of the next). At a limit, above all of these: compound 3.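

At the double-bonded chain carbon, 4-fluorophenyl in place of dimethylcarbamoyl gives an at least 5.4-fold lower number from compound 3 to compound 4 (0.73 log units; beyond the scatter), a step that rests on the limit for compound 3: the limit of > 1000 nM in this assay, at which 1 of the 4 values shown sits. Against 4-methyl-1,3-thiazol-5-yl at the same carbon, 4-fluorophenyl does not separate, a 1.2-fold lower number from compound 1 to compound 4 (0.09 log units; within the scatter), so these two different aromatic rings read alike here. On the aromatic carbon, 2-(4-fluorophenyl)ethenyl in place of 4-methoxyphenyl gives a 2.1-fold higher number from compound 2 to compound 4 (0.32 log units; beyond the scatter).

As far as these compounds go, how an amine or a carboxylic acid at the double-bonded chain carbon would read in this assay stays open. So does the contribution of the ethenyl link apart from the ring it carries.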